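The compounds below may be only part of what the source reports. "The series", "measured", "known", "first", "only" and "open" are said of these compounds alone.

Of the compounds shown here, three sharing one core have been measured in a functional assay on HeLa cells (Homo sapiens) for antiproliferative activity, read by MTT assay, with a stated time of 24 h; a lower number here means a stronger inhibitor, a higher number a weaker inhibitor. Compound 1 `CC1CCC(C(C)C)C(O[C@H]2OC(=O)C(Br)=C2Sc2nnc(-c3ccccc3O)s2)C1` gives 2900 nM, and compound 2 `CC1CCC(C(C)C)C(O[C@H]2OC(=O)C(Br)=C2Sc2nnc(-c3ccc(O)cc3)s2)C1` gives 2600 nM. Compound 3 `CC1(C)C2CCC1(C)C(O[C@H]1OC(=O)C(Br)=C1Sc1nnc(-c3ccco3)s1)C2` gives 1300 nM, the lowest of the three numbers; its gap to compound 2 lies within the scatter, its gap to compound 1 just beyond it. Compound 4 `CC1(C)C2CCC1(C)C(O[C@H]1OC(=O)C(Br)=C1Sc1nnc(-c3cccnc3)s1)C2` differs from compound 3 in one place: pyridin-3-yl in place of furan-2-yl on an aromatic carbon. Going by the values given here, the only measured step that alters the aromatic group at this position is a 1.1-fold lower number from compound 1 to compound 2 (0.05 log units; within the scatter), where exchanging one aromatic ring for another left the number within the scatter. Among the compounds with values here, no measured step trades a five-membered aromatic ring for a six-membered aromatic ring, so the expectation rests on that single step. For compound 4 the estimate is 1600 nM, with a range of 600 nM to 4500 nM. The expected step of a 1.2-fold higher number from compound 3 to compound 4 (0.09 log units; within the scatter) means no change beyond the scatter.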

Compound 4, half-maximal inhibitory concentration: 3400 nM
For compound 4 the middle estimate is 2.1-fold (0.33 log units) below the measured one, and the stated range covers the measured number.
By their numbers in this assay, from the lowest: compounds 3, 2, 1 and 4 (each within the scatter of the next, the first and the last beyond it).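

At this position, on the five-membered aromatic ring with 2 nitrogen and 1 sulfur, the choice of aromatic ring can matter: pyridin-3-yl in place of furan-2-yl gives a 2.6-fold higher number from compound 3 to compound 4 (0.42 log units; beyond the scatter) in this assay. This is the only step shown at this position that lies beyond the scatter, though it is modest in size. No measured evidence here explains the change. As far as these compounds go, it remains open whether ring size or the hetero atom matters more, and thiophen-2-yl or unsubstituted phenyl at this position could help separate the two. From the compounds shown here alone, how an open-chain amine would compare here also remains open.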